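Swapping the Five-Membered Ring on a Shared Nucleoside Core

The compounds below may be only part of what the source reports. "The series", "measured", "known", "first", "only" and "open" are said of these compounds alone.

Compound 3, `CSc1ncnc2c1c(-c1cccs1)cn2[C@@H]1O[C@H](CO)[C@@H](O)[C@H]1O`, carries a methylthio group and a thiophen-2-yl group on the shared core. In a functional assay on HCT-116 cells (Homo sapiens), read by MTT assay, with a stated time of 72 h (on this read-out lower numbers stand for stronger inhibition and higher numbers for weaker inhibition), compound 3 reaches only the limit of the measurement, > 20000 nM, so no number is known for it. Compound 1, `CNc1ncnc2c1c(-c1ccoc1)cn2[C@@H]1O[C@H](CO)[C@@H](O)[C@H]1O`, also stands at a limit in this assay, giving > 20000 nM. Compound 2, `COc1ncnc2c1c(-c1ccoc1)cn2[C@@H]1O[C@H](CO)[C@@H](O)[C@H]1O`, differs from compound 1 by a methoxy in place of methylamino on an aromatic carbon; in this assay compound 2 gives 130 nM, and that step is an at least 150-fold lower number from compound 1 to compound 2 (2.18 log units; beyond the scatter). Two of the three values shown sit at the limit of > 20000 nM in this assay, at which 2 of the 3 values shown sit.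

Compound 4, `CSc1ncnc2c1c(-c1ccoc1)cn2[C@@H]1O[C@H](CO)[C@@H](O)[C@H]1O`, has not yet been measured. It differs from compound 3 in one place: furan-3-yl in place of thiophen-2-yl on an aromatic carbon. No measured pair changes this ring, so no step shown bears directly on it; the one measured step alters a different group. Compound 2 shows that the furan-3-yl group, paired with methoxy, gives a number well within the range of this assay. Compound 3, with thiophen-2-yl and methylthio, sits at a limit. Compound 4 is therefore expected to give a lower number than compound 3, an at least 6.6-fold lower number from compound 3 to compound 4 (0.82 log units; beyond the scatter), though how far is uncertain. The estimate for compound 4 is 3000 nM, in a range from 300 nM to 20000 nM.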

Compound 4, half-maximal inhibitory concentration: 100 nM
The estimate for compound 4 lay 30-fold (1.48 log units) above the measured number; measured number outside the range, below it.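

In this assay the methylsulfanyl group stays the same while the five-membered ring changes, and furan-3-yl in place of thiophen-2-yl brings an at least 200-fold lower number from compound 3 to compound 4 (2.30 log units; beyond the scatter) even though both rings have the same count of heavy atoms, so the choice of ring at this position decides the outcome for this pair. Compound 3 and compound 1 each stand at a limit, not at a number: the limit of > 20000 nM in this assay, at which 2 of the 4 values shown sit. With furan-3-yl held fixed, methoxy and methylsulfanyl cannot be told apart, as a 1.3-fold lower number from compound 2 to compound 4 (0.11 log units; within the scatter) shows, whereas methylamino stands well apart from methylsulfanyl, with an at least 200-fold lower number from compound 1 to compound 4 (2.30 log units; beyond the scatter) as the step.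

The compounds shown do not separate the exchange of sulfur for oxygen from the change in how the ring is attached, and a thiophen-3-yl or furan-2-yl group would be needed to pull those two apart. As far as these compounds go, it also remains open how this furan-3-yl compound would respond to an ethoxy or a dimethylamino group in place of methylsulfanyl.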